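Halogen additions on the shared core: cytotoxicity notes

The compounds below may be only part of what the source reports. "The series", "measured", "known", "first", "only" and "open" are said of these compounds alone.

Measured so far:
compound 1 `O[C@@H]1Cc2ccccc2N[C@H](c2ccccc2)C1` — > 300000 nM
compound 2 `O[C@@H]1Cc2cc(Br)ccc2N[C@H](c2ccccc2)C1` — 42100 nM

In an ADME assay on Vero cells (Chlorocebus sabaeus) for cytotoxicity, read by MTT assay, with a stated time of 72 h (on this read-out higher numbers stand for lower toxicity in this test and lower numbers for higher toxicity in this test), compound 1 gives > 300000 nM, which is a limit of the assay and not a number. Compound 1 therefore stands only at the limit of > 300000 nM in this assay, at which 1 of the 2 values shown sits, with no fixed place among the numbers. Compound 3 `O[C@@H]1Cc2ccccc2N[C@H](c2ccccc2Cl)C1` differs from compound 1 by chloro in place of hydrogen on an aromatic carbon. Among the measured compounds shown here, the one measured step that bears on this is an at least 7.1-fold lower number from compound 1 to compound 2 (0.85 log units; beyond the scatter), a halogen entering at a different place on the shared core. For compound 3 the expected value is 150000 nM, between 50000 nM and 300000 nM. The estimated step of an at least 2.0-fold lower number from compound 1 to compound 3 (0.30 log units; that floor lies within the scatter) is expected to run in the same direction as the measured one, but smaller.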

Compound 3, half-maximal cytotoxic concentration: > 300000 nM
Compound 3: no number, only a limit; the forecaster's own chance of this, stated with the estimate: 40%; middle value at least 2.0-fold (0.30 log units) from the limit.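

Compound 1 and compound 3 both stand at a limit of the assay, so no step between them can be read: the limit of > 300000 nM in this assay, at which 2 of the 3 values shown sit.

On these data alone, whether chloro in place of hydrogen changes cytotoxicity on the shared core remains open.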